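Urea aryl trifluoromethyl position: compound 2 to compound 3

This account rests on a few compounds, and the source may have more. Where it says the series, first, only, none or still open, it means among the compounds named here.

Compound 2 `CN(C)CCn1cnnc1-c1cc(Oc2ccc(NC(=O)Nc3cccc(C(F)(F)F)c3)cc2F)ccn1` gives 77.7% in an assay on isolated protein for inhibition of proto-oncogene tyrosine-protein kinase receptor Ret (Homo sapiens), read by mobility shift assay, with a stated time of 1 h, tested at 10 uM (on this read-out lower numbers stand for less inhibition and higher numbers for more inhibition at the one concentration tested (going by the name of the read-out)), and compound 1 `CN(C)CCn1cnnc1-c1cc(Oc2ccc(NC(=O)Nc3ccc(Cl)c(C(F)(F)F)c3)cc2F)ccn1` gives 74.1%, the step of a number 3.6 percentage points higher from compound 1 to compound 2 (within the scatter) lying within the scatter, so the two stand level. Compound 3 `CN(C)CCn1cnnc1-c1cc(Oc2ccc(NC(=O)Nc3ccccc3C(F)(F)F)cc2F)ccn1` differs from compound 2 by 2-(trifluoromethyl)phenyl in place of 3-(trifluoromethyl)phenyl on an amide-type nitrogen. Within the data shown here, the single measured step, hydrogen in place of chloro, leaves the trifluoromethyl where it is, so no measured step bears on this change and the expectation rests on compound 2 alone. The expected step of a number 27.7 percentage points lower from compound 2 to compound 3 (beyond the scatter) is downward and uncertain, with a wide range. Compound 3 is estimated at 50%, between 15% and 85%.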

Compound 3, a percentage reported as inhibition, at one concentration (the size of the read-out at that concentration, not a potency): 43%
Estimate against measurement, compound 3: 7 percentage points above; the range from low to high includes it.
By their numbers in this assay, from the lowest: compound 3; then compounds 1 and 2 (each within the scatter of the next).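

In this assay, the position of the trifluoromethyl on the urea aryl matters: 2-(trifluoromethyl)phenyl in place of 3-(trifluoromethyl)phenyl on the amide-type nitrogen gives a number 34.7 percentage points lower from compound 2 to compound 3 (beyond the scatter), whereas removing the chloro stayed within the scatter. The change from 4-chloro-3-(trifluoromethyl)phenyl gives a similar result, a number 31.1 percentage points lower from compound 1 to compound 3 (beyond the scatter). Nothing available here accounts for this loss.

Open, as far as these compounds go, is whether a nitrile or a methoxy group in place of the trifluoromethyl would keep the read-out. Also open, from the compounds shown here alone, is how a morpholine in place of the dimethylamino group would read.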